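The source may hold more compounds than are shown below. What is called first, only, known or untested is meant among the compounds shown, and "the series" means these compounds.

The compounds share one core and differ only in the ring attached to the carbonyl carbon of the amide. Compound 1 `COc1cc2ncnc(Nc3ccc(NC(=O)c4cccc(C)c4)cc3)c2cc1OC` carries 3-methylphenyl there and in a functional assay on MCF7 cells (Homo sapiens) for inhibition, read by MTT assay (on this read-out higher numbers stand for weaker inhibition and lower numbers for stronger inhibition), compound 1 gives 13000 nM. Compound 2 `COc1cc2ncnc(Nc3ccc(NC(=O)c4ccccc4OC)cc3)c2cc1OC` carries 2-methoxyphenyl; in this assay compound 2 stops at > 100000 nM, which is a limit of the assay and not a number. Compound 3 `COc1cc2ncnc(Nc3ccc(NC(=O)c4ccc(C(C)(C)C)cc4)cc3)c2cc1OC` carries 4-(tert-butyl)phenyl; in this assay compound 3 likewise stops at the limit > 100000 nM. So compound 2 stands at the weak end of what has been shown, sharing its limit with compound 3 (the limit of > 100000 nM in this assay, at which 2 of the 3 values shown sit). The step of an at least 7.6-fold higher number from compound 1 to compound 2 (0.88 log units; beyond the scatter) records a weakening, the step of an at least 7.6-fold higher number from compound 1 to compound 3 (0.88 log units; beyond the scatter) records the same, and the step that the two limits leave unreadable from compound 2 to compound 3 cannot be read.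

Compound 4 `COc1cc2ncnc(Nc3ccc(NC(=O)c4cccc(F)c4)cc3)c2cc1OC` is not yet measured. Its change from compound 2 is 3-fluorophenyl in place of 2-methoxyphenyl on a carbonyl carbon. Among the compounds with values here, the 3-fluorophenyl of compound 4 parallels in name the 3-methylphenyl of compound 1, and the one measured step that bears on this move is an at least 7.6-fold higher number from compound 1 to compound 2 (0.88 log units; beyond the scatter) run backward; if it reverses, compound 4 should land near compound 1 rather than at the limit. Compound 4 is therefore expected to give 20000 nM in this assay, within 6000 nM to 80000 nM. That estimate means an expected step of an at least 5.0-fold lower number from compound 2 to compound 4 (0.69 log units; beyond the scatter).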

Compound 4, half-maximal inhibitory concentration: 13600 nM
Beside the measured number, compound 4's estimate is 1.5-fold (0.17 log units) above it, within the range that was stated.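

In this assay, within the data shown here, the swap of methyl for fluoro on the aromatic carbon gives a 1.0-fold higher number from compound 1 to compound 4 (0.02 log units; within the scatter), so 3-fluorophenyl and 3-methylphenyl cannot be told apart here, and compound 1 no longer stands alone as the only compound with a measurable number. The other two comparisons show how much the choice of ring matters at this place on the carbonyl carbon: 3-fluorophenyl in place of 2-methoxyphenyl gives an at least 7.3-fold lower number from compound 2 to compound 4 (0.86 log units; beyond the scatter), and 3-fluorophenyl in place of 4-(tert-butyl)phenyl gives an at least 7.3-fold lower number from compound 3 to compound 4 (0.86 log units; beyond the scatter). Among these four compounds, only the two groups named with a 3 give measurable values, while compound 2 and compound 3 remain at a limit of the assay and not at a number: the limit of > 100000 nM in this assay, at which 2 of the 4 values shown sit.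

On these data alone, whether this holds beyond methyl and fluoro stays open, for example with an amine or a carboxylic acid in place of the fluoro, or with a plain phenyl ring carrying no added group. The true distance of compound 2 and compound 3 from the measured compounds is also unknown, and the step between those two limits cannot be read.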